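Swapping Furan for Thiophene on Two Related Cores

This account rests on a few compounds, and the source may have more. Where it says the series, first, only, none or still open, it means among the compounds named here.

Compound 1 `CC1=C(C(=O)OC(C(F)(F)F)C(F)(F)F)C(c2ccoc2)NC(=O)N1` and compound 3 `CC1=C(C(=O)OC(C(F)(F)F)C(F)(F)F)C(c2cccs2)NC(=O)N1` share one core, while compound 2 `CC(C)OC(=O)C1=C(C(F)(F)F)NC(=O)NC1c1ccoc1` and compound 4 `CC(C)OC(=O)C1=C(C(F)(F)F)NC(=O)NC1c1cccs1` share another; the difference between the two cores is not broken down here. In an assay on HEK293 cells for displacement of a labelled ligand from adenosine receptor A2b (Homo sapiens), read by radioligand binding, with a stated time of 30 min, tested at 1 uM (on this read-out higher numbers stand for more inhibition at the one concentration tested (going by the name of the read-out) and lower numbers for less inhibition), compound 1 gives 2%, and compound 3 gives 1%. The change between these two is thiophen-2-yl in place of furan-3-yl on a saturated ring carbon, and it made a number 1 percentage points lower from compound 1 to compound 3 (within the scatter). Compound 2 reaches 37% in this assay, the highest of the three measured numbers. The change from compound 2 to compound 4 is thiophen-2-yl in place of furan-3-yl on a saturated ring carbon. For the measured compounds named here, it is the same kind of change as the one from compound 1 to compound 3, but the surroundings differ: in compound 2 the saturated ring carbon is next to the ring atom that bears an isopropoxycarbonyl group and two ring bonds from the ring atom that bears a trifluoromethyl group, whereas in compound 1 it is next to the ring atom that bears a large group and two ring bonds from the ring atom that bears a methyl group. Going by the values given here, only one measured example of this swap exists, and it was made on a different core, so the expectation carries real uncertainty. Compound 4 is expected to show a step of a number 4 percentage points lower from compound 2 to compound 4 (within the scatter) in this assay, kept small because the measured step of a number 1 percentage points lower from compound 1 to compound 3 (within the scatter) stayed small. Compound 4 is therefore estimated at 33%, with a range from 15% to 50%.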

Compound 4, a percentage reported as inhibition, at one concentration (the size of the read-out at that concentration, not a potency): 19%
Estimate against measurement, compound 4: 14 percentage points above; the range from low to high includes it.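

In this assay, putting thiophen-2-yl in place of furan-3-yl on the saturated ring carbon gave a number 18 percentage points lower from compound 2 to compound 4 (beyond the scatter), so on this core the swap lowered the inhibition seen at the one concentration tested. The swap therefore does not carry over from one core to the other with the same size, and a small step on one core was no safe guide to the step on the other: the same change on two cores in this assay, a number 1 percentage points lower (within the scatter) from compound 1 to compound 3 and a number 18 percentage points lower (beyond the scatter) from compound 2 to compound 4, 17 percentage points apart, beyond the scatter of two such steps. This does not show which difference between the two cores sets the size of the step, and one pair on each core gives no general rule for the series.

The swap itself alters two things at once, the hetero atom and the point where the ring is attached, so the compounds shown leave open which of these matters; thiophen-3-yl or furan-2-yl on the same saturated ring carbon would separate the two. They also leave open how inhibition would respond to a group of a different kind at that place, such as an amine or a carboxylic acid, on either core.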